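Bromo in place of trifluoromethyl: compound 2 to compound 3

A few compounds are considered here, and "the series" means these few. Any claim that something is new, unique, unknown or untested is made for them only; others in the source may bear on it.

compound 1 `CCOC(=O)c1c(-c2cccc(OCC)c2)[nH]c2cc(OC)ccc2c1=O` gives > 21500 nM
compound 2 `CCOC(=O)c1c(-c2cccc(C(F)(F)F)c2)[nH]c2cc(OC)ccc2c1=O` gives > 21500 nM

In an ADME assay on Raji cells (Homo sapiens) for cytotoxicity, read by luminescence, with a stated time of 72 h (on this read-out lower numbers stand for an effect already at smaller amounts and higher numbers for an effect only at larger amounts of compound), compound 1 gives > 21500 nM as a limit and not a number. Compound 2 stands at > 21500 nM in the same way, also a limit and not a number. The whole reading so far is the limit of > 21500 nM in this assay, at which 2 of the 2 values shown sit, with no number yet.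

Compound 3 `CCOC(=O)c1c(-c2cccc(Br)c2)[nH]c2cc(OC)ccc2c1=O` differs from compound 2 by bromo in place of trifluoromethyl on an aromatic carbon, counted as bromo in place of trifluoromethyl on an aromatic carbon in full. Within the data shown here, the one measured step that bears on this is a step that the two limits leave unreadable from compound 1 to compound 2 with trifluoromethyl in place of ethoxy on an aromatic carbon. It offers no size to carry over. No step beyond the scatter is expected in this assay because the limit of > 21500 nM in this assay, at which 2 of the 2 values shown sit, is all that the two groups have shown. The expected step is a step that the limit leaves unreadable from compound 2 to compound 3 and it may well stay unreadable. For compound 3 the estimate is 25000 nM with an expected range from 12000 nM to 50000 nM and the likeliest report is again a limit.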

Compound 3, half-maximal effective concentration: > 21500 nM
Compound 3 was reported as a limit; the forecaster's own chance of this, stated with the estimate: 85%; the middle value is on the limit's open side.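

Compound 1, compound 2 and compound 3 give no readable step between them in this assay, and the whole reading remains a single limit: the limit of > 21500 nM in this assay, at which 3 of the 3 values shown sit.

The compounds shown leave open whether any change to the group on the shared core would give a numerical value in this assay.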